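A Fluorine Step Carried to a Second Core

This account rests on a few compounds, and the source may have more. Where it says the series, first, only, none or still open, it means among the compounds named here.

Two closely related pairs share one change. Compound 1 `Oc1cccc2[nH]c(-c3ccc(-c4ccc(-c5ccccc5)cc4)cc3)nc12` and compound 2 `Oc1cccc2[nH]c(-c3ccc(-c4ccc(-c5ccc(F)cc5)cc4)cc3)nc12` differ only in this way: fluoro in place of hydrogen on an aromatic carbon. In a functional assay on KB cells (Homo sapiens) for inhibition, read by sulforhodamine B assay (on this read-out lower numbers stand for stronger inhibition of growth and higher numbers for weaker inhibition of growth), compound 1 gives 4010 nM, and compound 2 gives 6920 nM. The step of a 1.7-fold higher number from compound 1 to compound 2 (0.24 log units; within the scatter) is therefore small. Compound 3 `Cc1ccc2[nH]c(-c3ccc(-c4ccc(-c5ccccc5)cc4)cc3)nc2c1` carries a different core; how the two cores differ is not broken down here. In this assay compound 3 gives 32100 nM, which lies beyond the scatter from both compound 1 and compound 2, so compound 3 inhibits growth less strongly than either. Compound 4 `Cc1ccc2[nH]c(-c3ccc(-c4ccc(-c5ccc(F)cc5)cc4)cc3)nc2c1`, not yet measured, relates to compound 3 as compound 2 relates to compound 1: fluoro in place of hydrogen on an aromatic carbon. The place of the change is described in the same words for both pairs, so the change is the same. Among the measured compounds shown here, the expectation rests on the single earlier step: because a 1.7-fold higher number from compound 1 to compound 2 (0.24 log units; within the scatter) stayed within the scatter, the step of a 1.4-fold higher number from compound 3 to compound 4 (0.15 log units; within the scatter) is expected to be about as small. Compound 4 is thus expected to give 45000 nM, with a likely range from 20000 nM to 110000 nM.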

Compound 4, concentration for 50% growth inhibition: 24900 nM
Compound 4: the middle estimate sits 1.8-fold (0.26 log units) above what was measured, within the range that was stated.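

In this assay the change from phenyl to 4-fluorophenyl on the second core gives a 1.3-fold lower number from compound 3 to compound 4 (0.11 log units; within the scatter) and so stays within the usual scatter of repeated measurements, as it did on the first core. The two steps are printed with opposite signs, but that gap is not a real difference, so in these two pairs the change carries from one core to the other as a step too small to read: the same change on two cores in this assay, a 1.7-fold higher number (0.24 log units; within the scatter) from compound 1 to compound 2 and a 1.3-fold lower number (0.11 log units; within the scatter) from compound 3 to compound 4, 2.2-fold (0.35 log units) apart, within the scatter of two such steps. This does not show that fluoro has no effect at all, as a small true effect could lie hidden in the scatter, and two pairs give no rule for other cores in the series.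

From the compounds shown here alone, whether a chloro, a methoxy, an amine or a carboxylic acid in the same place would also carry unchanged from one core to the other remains open. Also open is whether the same holds for a fluoro on another ring of these compounds, or in other cell lines.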